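The compounds below may be only part of what the source reports. "The series", "measured", "known", "first", "only" and "open" are said of these compounds alone.

Compound 1 `Cc1ccc(-c2cn(CCC3(O)NC(=O)C(OCc4ccccc4)=C3OCc3ccccc3)nn2)cc1` carries a 4-methylphenyl on an aromatic carbon of the shared core. In a functional assay on U-937 cells (Homo sapiens) for antiproliferative activity, read by MTT assay, with a stated time of 24 h (a lower number here means a stronger inhibitor, a higher number a weaker inhibitor), compound 1 gives 54000 nM. Compound 2 `O=C1NC(O)(CCn2cc(C3=CCCCC3)nn2)C(OCc2ccccc2)=C1OCc1ccccc1` has cyclohex-1-en-1-yl in that same place. In this assay compound 2 reaches only a limit, > 100000 nM, so no exact number is known for it. The measured step between the two, an at least 1.8-fold higher number from compound 1 to compound 2 (0.26 log units; that floor lies within the scatter), is thus a floor rather than a measured size, and that floor lies within the usual scatter of this assay; this follows from the limit of > 100000 nM in this assay, at which 1 of the 2 values shown sits. Compound 2 therefore stands at the weak end of the numbers shown, with only a limit to describe it.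

Compound 3 `O=C1NC(O)(CCn2cc(Cc3ccccc3)nn2)C(OCc2ccccc2)=C1OCc1ccccc1` is the next step: benzyl in place of cyclohex-1-en-1-yl on an aromatic carbon. Within the data shown here, the only measured step on this part of the shared core, from compound 1 to compound 2, gave no clear movement beyond the scatter, so the expected step of a number no higher from compound 2 to compound 3 (the limit leaves the size open) is likewise small or none in this assay, and the limit is as likely as a number. Compound 3 is thus estimated at 100000 nM, within the range 40000 nM to 250000 nM.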

Compound 3, half-maximal inhibitory concentration: > 100000 nM
Compound 3: a limit, no number; the forecaster's own chance of this, stated with the estimate: 55%; the middle value sits exactly at the limit.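

Compound 3 reaches only a limit in this assay, > 100000 nM, so the six-membered aromatic ring of benzyl, taking the place of the non-aromatic ring of cyclohex-1-en-1-yl, yields no exact number at this position. Set against the 4-methylphenyl group, benzyl gives an at least 1.8-fold higher number from compound 1 to compound 3 (0.26 log units; that floor lies within the scatter), which is again a floor and not a measured size, so neither replacement of 4-methylphenyl is yet shown to differ from it beyond the scatter. The step between cyclohex-1-en-1-yl and benzyl cannot be read because both compounds stand at the same limit: the limit of > 100000 nM in this assay, at which 2 of the 3 values shown sit.

On these data alone, how far compound 2 and compound 3 truly lie from compound 1 stays open, since only exact values could give the size of those steps. Among these compounds, also open is whether an amine, a carboxylic acid or a longer chain on this aromatic carbon of the shared core would give an exact number, and whether that number would be lower or higher than the one for compound 1.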